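The compounds below may be only part of what the source reports. "The series", "measured", "known", "first", "only" and "open" are said of these compounds alone.

Measured so far in a functional assay on CHO cells for agonist activity at adenosine receptor A1 (Homo sapiens), read by fluorescence and ERK phosphorylation, with stated times of 30 min and 1.5 h, tested at 3 uM; a lower number here means a weaker effect, a higher number a stronger effect of the compound at the concentration tested:
compound 1 `Nc1scc(-c2cccc(C(F)(F)F)c2)c1C(=O)c1ccccc1` gives 83%
compound 2 `Nc1scc(-c2ccccc2)c1C(=O)c1ccccc1` gives 49%
compound 3 `Nc1scc(-c2ccccc2F)c1C(=O)c1ccccc1` gives 55%

Compound 3 stands second highest of the three numbers: compound 2 sits within the scatter of it, while compound 1 lies beyond the scatter, higher. Compound 4 `Nc1scc(-c2cccc(F)c2)c1C(=O)c1ccccc1` differs from compound 3 by 3-fluorophenyl in place of 2-fluorophenyl on an aromatic carbon. Among the compounds with values here, no measured step moves a fluorine between positions on that phenyl ring, so the bearing is indirect. The step of a number 34 percentage points lower from compound 1 to compound 2 (beyond the scatter) shows that a group on this ring can shift the read-out a great deal; the step of a number 6 percentage points higher from compound 2 to compound 3 (within the scatter) shows that a single fluoro need not. An upward step of modest size is expected in this assay, though one within the scatter cannot be excluded. Compound 4 is therefore estimated at 63%, between 46% and 80%, which means an expected step of a number 8 percentage points higher from compound 3 to compound 4 (within the scatter).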

Compound 4, a percentage reported as activity, at one concentration (the size of the read-out at that concentration, not a potency): 51%
Beside the measured number, compound 4's estimate is 12 percentage points above it; low and high end bracket the measured number.
By their numbers in this assay, from the lowest: compounds 2, 4 and 3 (each within the scatter of the next); then compound 1.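

In this assay, 3-fluorophenyl in place of 2-fluorophenyl gives a step with no readable effect of fluorine placement on this ring (a number 4 percentage points lower from compound 3 to compound 4 (within the scatter)). 3-Fluorophenyl also stays level with the unsubstituted phenyl (a number 2 percentage points higher from compound 2 to compound 4 (within the scatter)), while fluoro does not reproduce the read-out of trifluoromethyl (a number 32 percentage points lower from compound 1 to compound 4 (beyond the scatter)). No available evidence accounts for these steps. Open, from the compounds shown here alone, is whether the larger read-out of compound 1 belongs to trifluoromethyl alone or would also appear with chloro, methoxy or a nitrile on this ring. Also open, going by these compounds, is how 2-(trifluoromethyl)phenyl compares with the 3-substituted ring of compound 1.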